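Phenylsulfonyl in place of the aryl carbonyl: working notes

The source may hold more compounds than are shown below. What is called first, only, known or untested is meant among the compounds shown, and "the series" means these compounds.

compound 1 `COc1ccc(-c2cn3cc(C4=CCN(C(=O)C5CCCCC5)CC4)ccc3n2)cc1OC`: 8060 nM
compound 2 `COc1ccc(-c2cn3cc(C4=CCN(C(=O)c5ccc(Cl)cc5)CC4)ccc3n2)cc1OC`: 12200 nM

In a functional assay on HeLa cells (Homo sapiens) for antiproliferative activity, read by MTT assay, with a stated time of 48 h (a higher number here means a weaker inhibitor, a lower number a stronger inhibitor), compound 1 gives 8060 nM and compound 2 gives 12200 nM. Compound 2 holds the upper of the two numbers, yet a 1.5-fold higher number from compound 1 to compound 2 (0.18 log units; within the scatter) stays within the scatter, so the two cannot be separated. Compound 3 `COc1ccc(-c2cn3cc(C4=CCN(S(=O)(=O)c5ccccc5)CC4)ccc3n2)cc1OC` differs from compound 2 by phenylsulfonyl in place of (4-chlorophenyl)carbonyl on an amine nitrogen in a ring. Among the compounds with values here, no measured step touches the carbonyl itself; the only step known, a 1.5-fold higher number from compound 1 to compound 2 (0.18 log units; within the scatter), swaps groups on that carbonyl and is within the scatter, so no direction can be read from it and the uncertainty is wide. For compound 3 the expected step is a 1.0-fold lower number from compound 2 to compound 3 (0.01 log units; within the scatter), and its estimate is 12000 nM, with a range of 4000 nM to 40000 nM.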

Compound 3, half-maximal inhibitory concentration: 12600 nM
Estimate against measurement, compound 3: 1.1-fold (0.02 log units) below; measured number inside the range.
By their numbers in this assay, from the lowest: compounds 1, 2 and 3 (each within the scatter of the next).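

In this assay, within the data shown here, phenylsulfonyl in place of (4-chlorophenyl)carbonyl on the amine nitrogen in a ring gives a 1.0-fold higher number from compound 2 to compound 3 (0.01 log units; within the scatter), the first reading at this position with the carbonyl itself replaced. Against the cyclohexylcarbonyl group, the same position gives a 1.6-fold higher number from compound 1 to compound 3 (0.19 log units; within the scatter), so the three groups cannot be separated here. No supporting measurement bears on this result.

The step from compound 2 to compound 3 also removes the chlorine, leaving the contributions of the sulfonyl and the chlorine unresolved. From the compounds shown here alone, how an amine or a carboxylic acid on the phenyl ring of the phenylsulfonyl group would read remains open.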